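Compound 4: one more step from a series at its limit

The source may hold more compounds than are shown below. What is called first, only, known or untested is meant among the compounds shown, and "the series" means these compounds.

In an ADME assay on cells (Fibroblast, Gallus gallus) for cytotoxicity, read by CCK-8 assay, with a stated time of 48 h (a higher number here means that more compound is tolerated, a lower number that less compound is tolerated), compound 1 `CCC(CC)O[C@@H]1C=C(C(=O)O)C[C@H](NCc2ccc(C(C)C)cc2)[C@H]1NC(C)=O` gives > 200000 nM as a limit, not a number. Compound 2 `CCC(CC)O[C@@H]1C=C(C(=O)O)C[C@H](NCc2ccc(C(C)(C)C)cc2)[C@H]1NC(C)=O` gives > 200000 nM as a limit too. Compound 3 `CCC(CC)O[C@@H]1C=C(C(=O)O)C[C@H](NCc2ccc(SC(C)CC)cc2)[C@H]1NC(C)=O` gives > 200000 nM as a limit as well. Compound 3 therefore stands in the shared position of the limit of > 200000 nM in this assay, at which 3 of the 3 values shown sit, and no order among the three can be read.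

Compound 4 `CCC(CC)O[C@@H]1C=C(C(=O)O)C[C@H](NCc2ccc(Sc3ccccc3)cc2)[C@H]1NC(C)=O` keeps the rest of compound 3 and alters one group: phenyl in place of sec-butyl on a sulfur.

The closest evidence is a step that the two limits leave unreadable from compound 1 to compound 3 and a step that the two limits leave unreadable from compound 2 to compound 3, the two steps that bring in the (sec-butyl)sulfanyl group now being changed. The remaining step, a step that the two limits leave unreadable from compound 1 to compound 2, is of the same unreadable kind. Among the measured compounds shown here, none of them gives a size, and no measured compound carries phenylsulfanyl, so a lower reading for compound 4 stays open. For the measured compounds named here, with those three steps as the only guide, the estimated change is a number no higher from compound 3 to compound 4 (the limit leaves the size open), with no direction expected and nothing expected beyond the usual scatter. The expected value for compound 4 is 200000 nM, with an estimated range from 100000 nM to 400000 nM and another limit as the likeliest report.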

Compound 4, half-maximal cytotoxic concentration: > 200000 nM
Compound 4 ended at the assay's limit; the forecaster's own chance of this, stated with the estimate: 80%; the middle value sits exactly at the limit.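

In this assay compound 4 gives > 200000 nM, a limit and not a number. No step from compound 1, compound 2 or compound 3 to compound 4 can be read, because all four compounds share one position: the limit of > 200000 nM in this assay, at which 4 of the 4 values shown sit.

The compounds shown leave open how far apart the four lie beyond that limit, including whether phenylsulfanyl and (sec-butyl)sulfanyl differ at all.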